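Geometric isomer of a dimethylamino-substituted triazole glycoside

This account rests on a few compounds, and the source may have more. Where it says the series, first, only, none or still open, it means among the compounds named here.

Three acetylated glycoside triazoles have been examined in a functional assay on MCF7 cells (Homo sapiens) for cytotoxicity, read by sulforhodamine B assay, with a stated time of 48 h; on this read-out higher numbers stand for weaker inhibition and lower numbers for stronger inhibition. Compound 1 `CC(=O)OC[C@H]1O[C@@H](n2cc(CN3C(=O)/C(=C/c4ccc(C)cc4)c4ccccc43)nn2)[C@H](OC(C)=O)[C@@H](OC(C)=O)[C@@H]1OC(C)=O` reaches only a limit in this assay, > 100000 nM. Compound 2 `CC(=O)OC[C@H]1O[C@@H](n2cc(CN3C(=O)/C(=C/C=C/c4ccccc4)c4ccccc43)nn2)[C@H](OC(C)=O)[C@@H](OC(C)=O)[C@@H]1OC(C)=O` gives 53200 nM in this assay, and compound 3 `CC(=O)OC[C@H]1O[C@@H](n2cc(CN3C(=O)/C(=C\c4ccc(N(C)C)cc4)c4ccccc43)nn2)[C@H](OC(C)=O)[C@@H](OC(C)=O)[C@@H]1OC(C)=O` gives 29800 nM. On the numbers shown, compound 3 stands with compound 2, the two values lying within the scatter of each other; the value of compound 1 is a limit, as noted in the limit of > 100000 nM in this assay, at which 1 of the 3 values shown sits.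

Going by the values given here, the only measured step, an at least 1.8-fold lower number from compound 1 to compound 2 (0.27 log units; that floor lies within the scatter), concerns a change of the group on the double-bonded chain carbon and lies within the scatter.

Compound 4 `CC(=O)OC[C@H]1O[C@@H](n2cc(CN3C(=O)/C(=C/c4ccc(N(C)C)cc4)c4ccccc43)nn2)[C@H](OC(C)=O)[C@@H](OC(C)=O)[C@@H]1OC(C)=O` differs from compound 3 as follows: the two compounds have the same atoms and bonds and differ only in configuration as drawn: 1 of 6 stereo elements differ; a double bond is drawn Z in compound 3 and E in compound 4. Among the compounds with values here, no measured pair in this assay shows a change of double-bond geometry alone, so nothing among the measured steps bears directly on this change. Within the data shown here, the one measured step, being within the scatter, also gives no sign that small changes at this chain carbon move the read-out. The step from compound 3 to compound 4 is therefore expected to be a 1.0-fold higher number from compound 3 to compound 4 (0.00 log units; within the scatter), that is, no change beyond the scatter in this assay. Compound 4 is accordingly estimated at 30000 nM, with a range from 8000 nM to 100000 nM.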

Compound 4, half-maximal inhibitory concentration: 25200 nM
For compound 4 the middle estimate is 1.2-fold (0.08 log units) above the measured one; the range from low to high includes it.
By their numbers in this assay, from the lowest: compounds 4, 3 and 2 (each within the scatter of the next, the first and the last beyond it). At a limit, above all of these: compound 1.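

Going by these compounds alone, compound 3 and compound 4 give the first reading of double-bond geometry alone in this assay, and with a 1.2-fold lower number from compound 3 to compound 4 (0.07 log units; within the scatter) the two forms cannot be told apart, in a comparison that changes nothing else: the fact that compounds 3 and 4 differ only in the configuration as drawn.
The earlier step at this chain carbon stayed within the scatter, whereas 4-(dimethylamino)phenyl in place of 2-phenylethenyl gives a 2.1-fold lower number from compound 2 to compound 4 (0.32 log units; beyond the scatter), so a change of this group now registers between two measured numbers, though only modestly.
Dimethylamino in place of methyl on an aromatic carbon gives an at least 3.9-fold lower number from compound 1 to compound 4 (0.59 log units; beyond the scatter), and this size is only a floor, since compound 1 stands at a limit: the limit of > 100000 nM in this assay, at which 1 of the 4 values shown sits.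

From the compounds shown here alone, whether geometry stays equally silent with other groups on the chain carbon remains open, since only the dimethylamino pair has been read in both forms. Also open, going by these compounds, is how a carboxylic acid or a morpholine on that aromatic carbon would read, and whether hydroxyl groups in place of the acetates would move the number in this assay at all.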